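The compounds below may be only part of what the source reports. "The series", "measured", "known", "first", "only" and "open" are said of these compounds alone.

Measured so far:
compound 1 `COc1ccc(/C(=N/OC(C)=O)c2cccc3ccccc23)c(OC)c1OC`, which in a functional assay on HCT-116 cells (Homo sapiens) for inhibition, read by sulforhodamine B assay, with a stated time of 48 h (on this read-out higher numbers stand for weaker inhibition and lower numbers for stronger inhibition), gives 4980 nM
compound 2 `COc1ccc(/C(=N/O)c2cccc3ccccc23)c(OC)c1OC`, for which compound 2 gives 5880 nM
compound 3 `COc1ccc(C(c2ccc(OC(C)CN(C)C)cc2)c2cccc3ccccc23)c(OC)c1OC`, for which compound 3 gives 8410 nM

Compound 3 has the highest of the three numbers, yet its gaps to compound 2 and to compound 1 are both within the scatter, so no order among the three can be read from these values. Among the compounds with values here, the only step between measured compounds that differ in one place is a 1.2-fold higher number from compound 1 to compound 2 (0.07 log units; within the scatter), hydrogen in place of acetyl on an oxygen; it lies elsewhere in the structure than the change now considered.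

Compound 4 `COc1ccc(C(c2ccc(OCCO)cc2)c2cccc3ccccc23)c(OC)c1OC` differs from compound 3 by 2-hydroxyethyl in place of 1-((dimethylamino)methyl)ethyl on an oxygen on an aromatic ring. Within the data shown here, no measured step touches the group on this oxygen, so the expectation rests only on the flat picture across compounds 1 to 3, where a change on an oxygen left the number within the scatter. The step is therefore expected to stay within the scatter: a 1.2-fold lower number from compound 3 to compound 4 (0.08 log units; within the scatter). Compound 4 is estimated at 7000 nM, with a range from 3000 nM to 17000 nM.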

Compound 4, half-maximal inhibitory concentration: > 20000 nM
Compound 4 ended at the assay's limit (the forecaster's own chance of this, stated with the estimate: 10%); middle value at least 2.8-fold (0.45 log units) from the limit.
By their numbers in this assay, from the lowest: compounds 1, 2 and 3 (each within the scatter of the next). At a limit, above all of these: compound 4.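

Within the data shown here, the group on the oxygen on an aromatic ring is the first place where a single change goes beyond the scatter in this assay, with 2-hydroxyethyl in place of 1-((dimethylamino)methyl)ethyl: an at least 2.3-fold higher number from compound 3 to compound 4 (0.37 log units; beyond the scatter). For compound 4, > 20000 nM is a limit of the assay and not a number. The only earlier one-place step, a 1.2-fold higher number from compound 1 to compound 2 (0.07 log units; within the scatter), lies elsewhere in the structure and within the scatter, so this position is the only one shown to respond, and the full size of its step stays unknown: the limit of > 20000 nM in this assay, at which 1 of the 4 values shown sits.

The change removes the dimethylamino nitrogen and alters the chain at the same time, so the compounds shown do not separate these two parts of the step. A 2-(dimethylamino)ethyl group or a longer chain ending in a hydroxyl on the same oxygen would bear on that question.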